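Trading the benzyl fluorines of compound 3 for trifluoromethyl

The compounds below may be only part of what the source reports. "The series", "measured", "known", "first", "only" and "open" are said of these compounds alone.

Three related compounds have been measured: compound 1 `O=C(Nc1ccc(-c2cscn2)cc1)C1CCN(Cc2ccc(F)c(F)c2)C1`, compound 2 `O=C(Nc1ccc(-c2cscn2)cc1)C1CCCN(C(=O)c2ccc(F)c(F)c2)C1` and compound 3 `O=C(Nc1ccc(-c2cscn2)cc1)C1CCCN(Cc2cc(F)cc(F)c2)C1`. In a functional assay on A-375 cells (Homo sapiens) for activation, with a stated time of 3 days (a lower number here means that less compound is needed, a higher number that more compound is needed for the effect), compound 1 gives 8000 nM. Compound 2 gives > 20000 nM, which is a limit of the assay and not a number. Compound 3 gives 1500 nM, the lower of the two actual numbers, and its gap to compound 1 lies beyond the scatter.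

Going by the values given here, the only measured step is an at least 13-fold lower number from compound 2 to compound 3 (1.12 log units; beyond the scatter). It is large, but it exchanges the whole group on the amine nitrogen, including the carbonyl. Compound 4 `O=C(Nc1ccc(-c2cscn2)cc1)C1CCCN(Cc2cccc(C(F)(F)F)c2)C1` instead takes 3-(trifluoromethyl)phenyl in place of 3,5-difluorophenyl on a saturated chain carbon bound to an amine nitrogen in a ring. Among the compounds with values here, no measured step alters only the substituents on this aromatic ring. Resting on compound 3 at 1500 nM, no step beyond the scatter is expected in this assay. The expected change is a 1.3-fold higher number from compound 3 to compound 4 (0.12 log units; within the scatter). Compound 4 is estimated at 2000 nM, with an expected range from 600 nM to 7000 nM.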

Compound 4, half-maximal effective concentration: > 20000 nM
Compound 4 gave a limit, no number; the forecaster's own chance of this, stated with the estimate: 10%; at least 10-fold (1.00 log units) between middle value and limit.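

Compound 4 gives > 20000 nM in this assay, which is a limit of the assay and not a number. The earlier step from an amide-linked group to a benzyl group changed the carbonyl as well, whereas here the saturated chain carbon on the amine nitrogen stays in place and exchanging 3,5-difluorophenyl for 3-(trifluoromethyl)phenyl alone gives an at least 13-fold higher number from compound 3 to compound 4 (1.12 log units; beyond the scatter), so this position responds strongly to what the aromatic ring carries. How far the step truly reaches stays unresolved, as the read-out stops at its limit: the limit of > 20000 nM in this assay, at which 2 of the 4 values shown sit.

The compounds shown do not separate the loss of the two fluorines from the entry of trifluoromethyl. On these data alone, how a ring carrying a single fluorine, a methoxy group or a nitrile would behave at this position remains open.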